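The compounds below may be only part of what the source reports. "The series", "measured", "known", "first", "only" and "open" are said of these compounds alone.

Measured so far in a physicochemical assay for lipophilicity; a higher number here means a more lipophilic compound, a lower number a more polar compound:
compound 1 `CCOc1ccc2[nH]c(-c3ccccc3)c(C3=C(Br)C(=O)NC3=O)c2c1`: 2.77
compound 2 `CCCOc1ccc2[nH]c(-c3ccccc3)c(C3=C(Br)C(=O)NC3=O)c2c1`: 3.16

For the measured compounds named here, compound 2 stands highest of the two numbers measured; its nearest neighbour is compound 1, and the single step between them, a number 0.39 log units higher from compound 1 to compound 2 (beyond the scatter), lies beyond the scatter. That step is the only one available and it corresponds to one extra carbon on the saturated chain.

Compound 3 `CCCCCCOc1ccc2[nH]c(-c3ccccc3)c(C3=C(Br)C(=O)NC3=O)c2c1` is not yet measured. It differs from compound 2 as follows: propyl in place of hydrogen on a saturated chain carbon, three bonds along the chain from an oxygen on an aromatic ring. The change extends the same chain by three carbons, so it is the same kind of alteration as the step from compound 1 to compound 2, taken further out and repeated. A step in this assay that is clearly upward and larger than the measured one is therefore expected.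

For compound 3 the estimate is 4.3, range 3.9 to 4.7, which is expected to correspond to a step of a number 1.14 log units higher from compound 2 to compound 3 (beyond the scatter).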

Compound 3, partition coefficient: 4.08
Estimate against measurement, compound 3: 0.22 log units above; measured number inside the range.
By their numbers in this assay, from the lowest: compound 1; then compound 2; then compound 3.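

Along compound 1, compound 2 and compound 3, the numbers in this assay rise in the order of chain length, and none of the three goes against that order. For the compounds shown here, the step with propyl in place of hydrogen (a number 0.92 log units higher from compound 2 to compound 3 (beyond the scatter)) is larger than the single methyl step (a number 0.39 log units higher from compound 1 to compound 2 (beyond the scatter)), and the whole extension comes to a large step (a number 1.31 log units higher from compound 1 to compound 3 (beyond the scatter)), so no levelling-off is visible up to hexyl on this oxygen. No measurement given here accounts for the rise.

As far as these compounds go, whether a longer chain such as octyl continues the rise, and whether an amine or a carboxylic acid at the end of the chain reverses it, remains open. The compounds shown are read in this assay alone, so nothing here says how the hexyl chain fares in any other read-out.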